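Chloro to trifluoromethyl on the shared core: plasma free fraction

The source may report more compounds than this note shows. Statements on the series, on what has been measured and on what is new or still open speak of the compounds shown alone.

Compound 1 `COc1c(F)cccc1C1CCN(c2ccn3c(CC4CC4)nnc3c2Cl)CC1` is the reference for this step. In an ADME assay on a cell-free system (plasma, Rattus norvegicus) for protein binding (on this read-out higher numbers stand for a larger free fraction and lower numbers for a smaller free fraction), compound 1 gives < 0.01, which is a limit of the assay and not a number. The two measured neighbours of compound 1 differ from it only on the pendant aryl ring. Compound 2 `COc1c(C2CCN(c3ccn4c(CC5CC5)nnc4c3Cl)CC2)ccc(F)c1F` gives < 0.01 in this assay, again a limit. Compound 3 `COc1c(F)ccc(F)c1C1CCN(c2ccn3c(CC4CC4)nnc3c2Cl)CC1` gives < 0.01 in this assay, also a limit. The steps are therefore a step that the two limits leave unreadable from compound 1 to compound 2 and a step that the two limits leave unreadable from compound 1 to compound 3, and between the neighbours a step that the two limits leave unreadable from compound 2 to compound 3; none of them can be sized, because all three values sit at the limit of < 0.01 in this assay, at which 3 of the 3 values shown sit.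

Compound 4 `COc1c(F)cccc1C1CCN(c2ccn3c(CC4CC4)nnc3c2C(F)(F)F)CC1` differs from compound 1 in one place: trifluoromethyl in place of chloro on an aromatic carbon. No measured step touches this position on the shared core, and none of the measured steps moved a value away from the limit, so the measured steps give no reason to expect a readable change in this assay here. For compound 4 the estimated unbound fraction is 0.006, with a range from 0.002 to 0.015. The step this estimate implies, a step that the limit leaves unreadable from compound 1 to compound 4, is expected to stay within the scatter, and a limit rather than a number is the more likely report.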

Compound 4, unbound fraction: < 0.01
Compound 4: a limit, no number; the forecaster's own chance of this, stated with the estimate: 80%; the middle value does not contradict the limit.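

In this assay compound 4 gives < 0.01, a limit and not a number. The step between compound 1 and compound 4 cannot be read, because both values are limits: the limit of < 0.01 in this assay, at which 4 of the 4 values shown sit.

The compounds shown leave open whether trifluoromethyl and chloro on the shared core differ at all in unbound fraction.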